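Tail flick activity: extending the glycinamide of compound 2

This account rests on a few compounds, and the source may have more. Where it says the series, first, only, none or still open, it means among the compounds named here.

Measured compounds in a functional assay on the whole organism (Tail, strain ICR) with Mus musculus as the target, in the tail flick test, with a stated time of 120 min, at a dose of 25 umol/kg by the oral route; a higher number here means a stronger effect of the compound at the dose given, a lower number a weaker effect:
- compound 1, `O=C(O)[C@@H]1CCCN1C(=O)CN(c1nc(Cl)nc2[nH]cnc12)C1CC1`, gives 23.6%
- compound 2, `O=C(CN(c1ncnc2c1ncn2C1CCCCO1)C1CC1)NCC(=O)OCc1ccccc1`, gives 17.2%
- compound 3, `O=C(CN(c1nc(Cl)nc2[nH]cnc12)C1CC1)N[C@@H](CCC(=O)OCc1ccccc1)C(=O)OCc1ccccc1`, gives 45.9%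

Compound 2 stands lowest of the three numbers in this assay. Its nearest neighbour is compound 1, whose value lies higher by an amount within the usual scatter, so no order between compound 1 and compound 2 can be read from these two values. Compound 3 lies furthest away, higher by an amount beyond the scatter.

Compound 4, `CC(C)(C)OC(=O)NCCCC[C@H](NC(=O)CN(c1ncnc2c1ncn2C1CCCCO1)C1CC1)C(=O)OCc1ccccc1`, has not been measured in this assay. It differs from compound 2 in one place: 4-((tert-butoxycarbonyl)amino)butyl in place of hydrogen on a saturated chain carbon bound to an amide-type nitrogen and a carbonyl carbon. For the measured compounds named here, no step between measured compounds that differ in only one place is available, so the expected size of this step rests only on the three values shown. Because compound 3, the compound carrying the larger amino-acid-derived chain, gives 45.9%, a modest upward step is expected. The step from compound 2 to compound 4 is estimated as a number 10.8 percentage points higher from compound 2 to compound 4 (beyond the scatter). Compound 4 is expected to give 28% in this assay, with a range from 10% to 50%.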

Compound 4, a percentage reported as activity, at one dose (the size of the read-out at that dose, not a potency): 28.4%
Beside the measured number, compound 4's estimate is 0.4 percentage points below it, within the range that was stated.
By their numbers in this assay, from the lowest: compounds 2, 1 and 4 (each within the scatter of the next, the first and the last beyond it); then compound 3.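

In this assay, the saturated chain carbon bound to an amide-type nitrogen and a carbonyl carbon proves open to substitution: 4-((tert-butoxycarbonyl)amino)butyl in place of hydrogen gives a number 11.2 percentage points higher from compound 2 to compound 4 (beyond the scatter) and thus a modest gain. For the compounds shown here, this is the only step here that changes a single place, so it is the first direct reading of this position, and it shows that adding these 12 heavy atoms there does not lower the read-out at this dose. Nothing at hand bears on why the number moves.

From the compounds shown here alone, whether the gain belongs to this particular chain or to any substituent on that carbon remains open, and a methyl group or the free aminobutyl chain with its primary amine would separate the two. Also open, going by these compounds, is whether a carboxylic acid in place of the benzyl ester would keep the gain.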